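Removing the substituted benzoyl ring's groups: compound 3 to compound 4

The source may hold more compounds than are shown below. What is called first, only, known or untested is meant among the compounds shown, and "the series" means these compounds.

In a functional assay on MOLT-4 cells (Homo sapiens) for inhibition, read by sulforhodamine B assay, with a stated time of 48 h (on this read-out lower numbers stand for stronger inhibition of growth and higher numbers for weaker inhibition of growth), the series reads as follows:
compound 1 `COc1cc(-c2nn(-c3cccc(NC(=O)c4cccc(C(F)(F)F)c4)c3)cc2-c2ccncc2)ccc1Cl`: 2010 nM
compound 2 `COc1cc(-c2nn(-c3cccc(NC(=O)Nc4ccc(Cl)c(Cl)c4)c3)cc2-c2ccncc2)ccc1Cl`: 1100 nM
compound 3 `COc1cc(-c2nn(-c3cccc(NC(=O)c4ccc(Cl)c(C(F)(F)F)c4)c3)cc2-c2ccncc2)ccc1Cl`: 5240 nM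

Compound 3 carries the highest of the three numbers, and its gaps to both others lie beyond the scatter. The change to compound 4 `COc1cc(-c2nn(-c3cccc(NC(=O)c4ccccc4)c3)cc2-c2ccncc2)ccc1Cl` is phenyl in place of 4-chloro-3-(trifluoromethyl)phenyl on a carbonyl carbon. The closest evidence is the chloro in place of hydrogen on an aromatic carbon (a 2.6-fold higher number from compound 1 to compound 3 (0.42 log units; beyond the scatter)), and compound 4 also lacks that chloro. The change on the same carbonyl carbon (a 4.8-fold higher number from compound 2 to compound 3 (0.68 log units; beyond the scatter)) also bears on it. Among the compounds with values here, no measured step isolates loss of the trifluoromethyl. A small move to a lower number is expected in this assay, estimated as (a 2.1-fold lower number from compound 3 to compound 4 (0.32 log units; beyond the scatter)). Compound 4 is estimated at 2500 nM (expected range 800 nM to 7500 nM).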

Compound 4, concentration for 50% growth inhibition: 701 nM
Beside the measured number, compound 4's estimate is 3.6-fold (0.55 log units) above it; measured number below the stated range.
By their numbers in this assay, from the lowest: compounds 4, 2 and 1 (each within the scatter of the next, the first and the last beyond it); then compound 3.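

In this assay, the bare phenyl on the carbonyl carbon gives a lower number than the 4-chloro-3-(trifluoromethyl)phenyl group (a 7.5-fold lower number from compound 3 to compound 4 (0.87 log units; beyond the scatter)), and losing trifluoromethyl alone also lowers it (a 2.9-fold lower number from compound 1 to compound 4 (0.46 log units; beyond the scatter)), so these compounds show no gain from either substituent. Phenyl and (3,4-dichlorophenyl)amino on the carbonyl carbon do not separate (a 1.6-fold lower number from compound 2 to compound 4 (0.20 log units; within the scatter)). Nothing available explains these steps.

On these data alone, a lone chloro on that phenyl remains untested in these compounds, so its effect without trifluoromethyl is open. As far as these compounds go, whether a methoxy, an amine or a carboxylic acid on that ring would hold the number also remains open.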